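This account rests on a few compounds, and the source may have more. Where it says the series, first, only, none or still open, it means among the compounds named here.

Measured so far in a functional assay on U-87MG ATCC cells for antiproliferative activity against U-87 MG (Homo sapiens), read by MTT assay, with a stated time of 48 h, tested at 50 uM; a lower number here means a stronger effect, a higher number a weaker effect of the compound at the concentration tested:
compound 1 `COc1ccc(-c2nc(C)c(C(=O)CSc3nc(-c4ccc(Cl)cc4)c(C#N)c(=O)[nH]3)s2)cc1`, 48%;
compound 2 `COc1ccc(-c2nc(C)c(C(=O)CSc3nc(-c4ccc(OC)c(OC)c4)c(C#N)c(=O)[nH]3)s2)cc1`, 22.2%.

Among the compounds with values here, compound 2 stands lowest of the two numbers, and its single step to compound 1 lies beyond the scatter. Compound 3 `COc1ccc(-c2nc(C)c(C(=O)CSc3nc(-c4ccccc4)c(C#N)c(=O)[nH]3)s2)cc1` differs from compound 2 by phenyl in place of 3,4-dimethoxyphenyl on an aromatic carbon. Within the data shown here, one measured step bears on this change, a number 25.8 percentage points lower from compound 1 to compound 2 (beyond the scatter), which altered the same aryl group and shows that this part of the molecule moves the read-out. The dimethoxy groups that now leave arrived with that drop, so a move back toward compound 1 seems likely. For compound 3 the expected step is a number 15.8 percentage points higher from compound 2 to compound 3 (beyond the scatter). Compound 3 is therefore estimated at 38%, with a range from 20% to 60%.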

Compound 3, a percentage reported as activity, at one concentration (the size of the read-out at that concentration, not a potency): 72.5%
Estimate against measurement, compound 3: 34.5 percentage points below; the whole stated range lies below it.
By their numbers in this assay, from the lowest: compound 2; then compound 1; then compound 3.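

In this assay, stripping the aryl ring bare raises the number from both substituted compounds: a number 50.3 percentage points higher from compound 2 to compound 3 (beyond the scatter), and a number 24.5 percentage points higher from compound 1 to compound 3 (beyond the scatter). The aryl group is therefore not simply better with fewer substituents: both 4-chlorophenyl and 3,4-dimethoxyphenyl give a stronger effect than plain phenyl, with 3,4-dimethoxyphenyl ahead. No measurement here explains this. Still open, as far as these compounds go, is whether a single methoxy group would account for most of the gain, and how an amine or a carboxylic acid on this phenyl ring would compare.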